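The compounds below may be only part of what the source reports. "The series", "measured", "known", "first", "only" and "open" are said of these compounds alone.

In a functional assay on OVCAR-5 cells (Homo sapiens) for inhibition, read by CCK-8 assay, with a stated time of 72 h, tested at 1 uM (on this read-out higher numbers stand for more inhibition of growth at the one concentration tested and lower numbers for less inhibition of growth), three compounds have been measured so far. Compound 1 `CN(C)C(=O)c1cc2cnc(Nc3ccc(N)cn3)nc2n1C1CCCC1` gives 12.3%, compound 3 `Nc1ccc(NC(=O)C2(C(=O)Nc3ccc(F)cc3)CC2)cc1F` gives 6.7%, and compound 2 `CN(C)C(=O)c1cc2cnc(Nc3ccc(NC(=O)C4(C(=O)Nc5cccc(F)c5)CC4)cc3)nc2n1C1CCCC1` gives 26.3%. That last number is the highest of the three, and its gaps to the other two lie beyond the scatter. No two of these compounds differ in only one place, so no measured step is available as a guide. Compound 4 `CN(C)C(=O)c1cc2cnc(Nc3ccc(NC(=O)C4(C(=O)Nc5ccc(Cl)c(C(F)(F)F)c5)CC4)cc3)nc2n1C1CCCC1` departs from compound 2 at a single place: 4-chloro-3-(trifluoromethyl)phenyl in place of 3-fluorophenyl on an amide-type nitrogen. In words, 4-chloro-3-(trifluoromethyl)phenyl stands in place of 3-fluorophenyl on an amide-type nitrogen. The starting point for the expectation is therefore compound 2 itself, at 26.3%. The expected change in this assay is a modest rise, which may not clear the scatter, and the estimated size is a number 8.7 percentage points higher from compound 2 to compound 4 (within the scatter). For the measured compounds named here, with no measured precedent for this exchange, the uncertainty is wide. Compound 4 is expected to give about 35%, with an estimated range from 15% to 60%.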

Compound 4, percent growth inhibition at one concentration: -2.4%
For compound 4 the middle estimate is 37.4 percentage points above the measured one, and the stated range ends above it.
By their numbers in this assay, from the lowest: compounds 4, 3 and 1 (each within the scatter of the next, the first and the last beyond it); then compound 2.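

In this assay, for the compounds shown here, the aryl group on the amide-type nitrogen proves able to change the result: 4-chloro-3-(trifluoromethyl)phenyl in place of 3-fluorophenyl gives a number 28.7 percentage points lower from compound 2 to compound 4 (beyond the scatter) as the only readable step at this position. With the rest of the structure unchanged, compound 4 gives -2.4% and so keeps none of the growth inhibition seen with compound 2 at the one concentration tested. Nothing available accounts for this loss.

With a single exchange at this position, the compounds shown do not separate the part played by the chloro substituent from that of the trifluoromethyl group. Going by these compounds, it remains open whether an unsubstituted phenyl, a 4-methoxyphenyl or a 3-aminophenyl on this nitrogen would keep, raise or lose the inhibition.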